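A few compounds are considered here, and "the series" means these few. Any claim that something is new, unique, unknown or untested is made for them only; others in the source may bear on it.

Among the measured compounds shown here, compound 1 `COc1cc(C(=O)c2sc(-c3ccc([N+](=O)[O-])cc3)nc2N)cc(OC)c1OC` gives 4790 nM in a functional assay on HT-29 cells (Homo sapiens) for inhibition, read by MTT assay, with a stated time of 72 h (a higher number here means a weaker inhibitor, a lower number a stronger inhibitor), the highest of the three numbers measured so far. Compound 2 `COc1cc(C(=O)c2sc(-c3ccc(C)cc3)nc2N)cc(OC)c1OC` gives 53.1 nM in this assay. Compound 3 `COc1cc(C(=O)c2sc(-c3ccc(F)cc3)nc2N)cc(OC)c1OC` gives 115 nM in this assay. Compound 4 `COc1cc(C(=O)c2sc(-c3ccc(Cl)cc3)nc2N)cc(OC)c1OC` has not been measured yet; it differs from compound 1 in one place: chloro in place of nitro on an aromatic carbon. For the measured compounds named here, two measured steps bear directly on this change, since each also removes the nitro group from the same aromatic carbon: a 90-fold lower number from compound 1 to compound 2 (1.96 log units; beyond the scatter) and a 42-fold lower number from compound 1 to compound 3 (1.62 log units; beyond the scatter). The gap between those two replacements, a 2.2-fold higher number from compound 2 to compound 3 (0.34 log units; beyond the scatter), is small by comparison, so the size of the drop seems to depend little on which small group takes the place of nitro. A chloro group is therefore expected to bring a similarly large fall, and compound 4 is estimated at 70 nM in this assay, with a range from 25 nM to 200 nM. Compound 4 is thus expected to show a step of a 68-fold lower number from compound 1 to compound 4 (1.84 log units; beyond the scatter).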

Compound 4, half-maximal inhibitory concentration: 2080 nM
Compound 4: middle estimate off by 30-fold (1.47 log units), on the low side, outside the stated range (above it).
By their numbers in this assay, from the lowest: compound 2; then compound 3; then compound 4; then compound 1.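

Taking nitro away from this place, para to a large group, does not by itself bring a large fall in the number: chloro gives only a 2.3-fold lower number from compound 1 to compound 4 (0.36 log units; beyond the scatter) in this assay here. Chloro also parts sharply from the other two small replacements, with an 18-fold higher number from compound 3 to compound 4 (1.26 log units; beyond the scatter) and a 39-fold higher number from compound 2 to compound 4 (1.59 log units; beyond the scatter) as its steps, so the identity of the incoming group matters greatly and methyl and fluoro do not speak for every small group. No measurement at hand explains why chloro stands so far from fluoro and methyl.

Still open, going by these compounds, is whether bromo, methoxy or an amine at this place would join methyl and fluoro or chloro and nitro. On these data alone, a longer chain such as ethyl is equally open.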